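The source may hold more compounds than are shown below. What is called first, only, known or untested is meant among the compounds shown, and "the series" means these compounds.

Compound 2 `Cc1cc(=O)n(-c2cccc(F)c2)nc1C(=O)Nc1ccc(Oc2ncnc3ccsc23)cc1` was tested in a functional assay on HepG2 cells (Homo sapiens) for cytotoxicity, read by MTT assay, with a stated time of 72 h (on this read-out higher numbers stand for weaker inhibition and lower numbers for stronger inhibition), and gave 10200 nM. Among the measured compounds shown here, the only other compound measured in this assay is compound 1 `Cc1cc(=O)n(-c2ccccc2C(F)(F)F)nc1C(=O)Nc1ccc(Oc2ncnc3ccsc23)cc1`, which gave 9230 nM. These two numbers cannot be told apart, since the step of a 1.1-fold higher number from compound 1 to compound 2 (0.04 log units; within the scatter) lies within the scatter, so compound 2 stands level with compound 1. Compound 3 `Cc1ccc(-n2nc(C(=O)Nc3ccc(Oc4ncnc5ccsc45)cc3)c(C)cc2=O)cc1` has not yet been measured in this assay. It differs from compound 2 in one place: 4-methylphenyl in place of 3-fluorophenyl on an aromatic nitrogen. For the measured compounds named here, the one measured step that bears on this change is the swap of the group on the same aromatic nitrogen, a 1.1-fold higher number from compound 1 to compound 2 (0.04 log units; within the scatter), which left the number essentially unchanged. On that basis no step beyond the scatter is expected here either, in either direction, and compound 3 is estimated at 10000 nM, with a range from 4000 nM to 25000 nM. The expected step is therefore a 1.0-fold lower number from compound 2 to compound 3 (0.01 log units; within the scatter).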

Compound 3, half-maximal inhibitory concentration: 25000 nM
The estimate for compound 3 lay 2.5-fold (0.40 log units) below the measured number, and the stated range covers the measured number.
By their numbers in this assay, from the lowest: compounds 1 and 2 (each within the scatter of the next); then compound 3.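

In this assay the group on this aromatic nitrogen turns out not to be freely exchangeable: 4-methylphenyl in place of 3-fluorophenyl gives a 2.5-fold higher number from compound 2 to compound 3 (0.39 log units; beyond the scatter) and so a modest weakening, something the earlier swap, which stayed within the scatter, gave no sign of. Measured against the 2-(trifluoromethyl)phenyl group, the same 4-methylphenyl group gives a 2.7-fold higher number from compound 1 to compound 3 (0.43 log units; beyond the scatter) and so a weakening of similar size, which makes compound 3 the weakest of the three here. No measurement at hand explains this shift.

Among the compounds shown here, with only three groups at this position, the methyl group and its place on the ring cannot be separated as the source of the change. On these data alone, how a plain phenyl ring, or a phenyl ring carrying an amine or a carboxylic acid, would behave here remains open.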